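Swapping the bicyclic ring on the benzylic arm: solubility outlook

The source may hold more compounds than are shown below. What is called first, only, known or untested is meant among the compounds shown, and "the series" means these compounds.

Measured so far:
- compound 1 `CNC(=O)c1cc(C(N)=O)cn(Cc2ccccc2)c1=O`: 71 ug/mL
- compound 2 `CNC(=O)c1cc(C(=O)NC2CC2)cn(Cc2nccc3[nH]ccc23)c1=O`: 73 ug/mL
- compound 3 `CNC(=O)c1ccc(=O)n(Cc2ccccc2)c1`: >= 108 ug/mL

In a physicochemical assay for solubility (a higher number here means a more soluble compound, a lower number a less soluble compound), compound 2 gives 73 ug/mL. Compound 1 gives 71 ug/mL in this assay, and the two numbers sit within the usual scatter of one another, so neither can be called the more soluble. For compound 3 the value in this assay is a limit of the assay, not a number, as noted in the limit of >= 108 ug/mL in this assay, at which 1 of the 3 values shown sits.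

Compound 4 `CNC(=O)c1cc(C(=O)NC2CC2)cn(Cc2cccc3occc23)c1=O` has not yet been measured in this assay. It differs from compound 2 in one place: a group of 9 heavy atoms (8 carbon, 1 oxygen; one five-membered aromatic ring with 1 hetero atom, one six-membered aromatic ring of carbon only) in place of a group of 9 heavy atoms (7 carbon, 2 nitrogen; one five-membered aromatic ring with 1 hetero atom, one six-membered aromatic ring with 1 hetero atom), on a saturated chain carbon bound to an aromatic nitrogen. Going by the values given here, no step between two measured compounds tracks this exact change, so the expectation rests on the structural change alone.

The expected step from compound 2 to compound 4 is a 2.9-fold lower number from compound 2 to compound 4 (0.47 log units; beyond the scatter), a drop beyond the scatter. Compound 4 is estimated at 25 ug/mL in this assay, with a likely range from 8 ug/mL to 80 ug/mL.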

Compound 4, solubility: >= 110 ug/mL
Compound 4 was reported as a limit (the forecaster's own chance of this, stated with the estimate: 10%); middle value at least 4.4-fold (0.64 log units) away from the limit.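

In this assay the value of compound 4 is a limit of the assay and not a number: the limit of >= 110 ug/mL in this assay, at which 1 of the 4 values shown sits. Going by these compounds alone, this gives the first step at this position that can be read between two measured compounds, an at least 1.5-fold higher number from compound 2 to compound 4 (0.17 log units; that floor lies within the scatter), and because that floor lies within the scatter, it does not establish a rise, though no fall appears. The group that leaves has 1 hydrogen-bond donor and 1-benzofuran-4-yl has 0 hydrogen-bond donors, yet the number did not go down in this one pair.

As far as these compounds go, how far the true value of compound 4 lies past its limit stays open, so the full size of the step is unknown. Also open, from the compounds shown here alone, is what a primary amine or a carboxylic acid on the 1-benzofuran-4-yl ring would do to the read-out.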